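The compounds below may be only part of what the source reports. "The series", "measured", "known", "first", "only" and "open" are said of these compounds alone.

Compound 1 `OC[C@H]1O[C@@H](n2cnc3c(NC4CCCC4)nc(NCCOCc4ccccc4)nc32)[C@H](O)[C@@H]1O` belongs to a small group of purine nucleosides examined in an ADME assay on L6 cells (Rattus norvegicus) for cytotoxicity; a higher number here means a weaker inhibitor, a lower number a stronger inhibitor. In this assay compound 1 gives 78800 nM, the only single number among the three results shown. Compound 3 `CCCCCNc1nc(NCCCCC)c2ncn([C@@H]3O[C@H](CO)[C@@H](O)[C@H]3O)c2n1` carries a value that is a limit of the assay rather than a number: in this assay compound 3 gives > 200000 nM. Compound 2 `OC[C@H]1O[C@@H](n2cnc3c(NCCC(c4ccccc4)c4ccccc4)nc(NC4CCCC4)nc32)[C@H](O)[C@@H]1O` has no single number in this assay: for compound 2 the entry reads "not determined" (no result reported). Compound 1 therefore stands alone with a measured figure, with one further value sitting at the limit described by the limit of > 200000 nM in this assay, at which 1 of the 3 values shown sits.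

Compound 4 `OC[C@H]1O[C@@H](n2cnc3c(Nc4ccccc4)nc(NCCOCc4ccccc4)nc32)[C@H](O)[C@@H]1O` has not yet been measured in this assay. It differs from compound 1 in one place: phenyl in place of cyclopentyl on a nitrogen on an aromatic ring.

Among the compounds with values here, with no step between measured compounds available, the expected move is small, no larger than the scatter of repeated measurements, in either direction. The estimated shift from compound 1 to compound 4 is a 1.0-fold higher number from compound 1 to compound 4 (0.01 log units; within the scatter). Compound 4 is expected to give about 80000 nM in this assay, within a range of 30000 nM to 200000 nM.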

Compound 4, half-maximal inhibitory concentration: 53800 nM
For compound 4 the middle estimate is 1.5-fold (0.17 log units) above the measured one, and the stated range covers the measured number.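

In this assay, the change from cyclopentyl to phenyl on a nitrogen on an aromatic ring reads as a 1.5-fold lower number from compound 1 to compound 4 (0.17 log units; within the scatter). With this step the position has two measured numbers rather than one, and a six-membered aromatic ring of carbon and a five-membered non-aromatic ring of carbon cannot be told apart here. Only compound 3 stands at a limit of the assay and not at a number: the limit of > 200000 nM in this assay, at which 1 of the 4 values shown sits.

From the compounds shown here alone, it remains open whether any other group on this nitrogen, such as a benzyl group, a pyridyl ring or a longer alkyl chain, would give a step beyond the scatter. Going by these compounds, it is also open whether the same change would read alike if the second side chain on the shared core ended in an amine or a carboxylic acid.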